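Shortening the chain and swapping the terminal group on a shared core

This account rests on a few compounds, and the source may have more. Where it says the series, first, only, none or still open, it means among the compounds named here.

Measured so far:
compound 1, `CC/N=C(\S)NCCCCCCn1nc(-c2ccccc2)ccc1=O`, -5.6%
compound 2, `CC/N=C(/NC#N)NCCCCn1nc(-c2ccccc2)c(C)cc1=O`, 38.8%

Two compounds on a shared core have been run in a functional assay on the whole organism with Rattus norvegicus as the target, at a dose of 100 mg/kg; a lower number here means less inhibition, a higher number more inhibition at the dose given (going by the name of the read-out). Compound 1 gives -5.6%, the lowest of the two numbers, and compound 2 gives 38.8%, a gap that lies beyond the usual scatter of this kind of measurement. The two compounds differ in several places at once, so the data do not show which change carries that gap.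

Compound 3, `N#CNC(=N)NCCCCn1nc(-c2ccccc2)ccc1=O`, has not yet been measured. It departs from compound 1 in one region: a group of 6 heavy atoms (2 carbon, 4 nitrogen; no ring) in place of a group of 8 heavy atoms (5 carbon, 2 nitrogen, 1 sulfur; no ring), on a saturated chain carbon, four bonds along the chain from an aromatic nitrogen. The group that enters in compound 3 closely resembles the terminal group of compound 2, and the chain length of compound 3 matches that of compound 2 as well, while the core of compound 3 matches that of compound 1.

On these two points alone, the step from compound 1 to compound 3 is expected to be upward and beyond the scatter, a number 30.6 percentage points higher from compound 1 to compound 3 (beyond the scatter), because compound 2 gives 38.8%. Compound 3 is therefore estimated at 25%, with a range from 0% to 50%.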

Compound 3, a percentage reported as inhibition, in the whole organism at one dose (the size of the read-out at that dose, not a potency): 61.2%
Compound 3: middle estimate off by 36.2 percentage points, on the low side; the whole stated range lies below it.
By their numbers in this assay, from the lowest: compound 1; then compound 2; then compound 3.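

On the core of compound 1, with nothing else altered, putting a group of 6 heavy atoms (2 carbon, 4 nitrogen; no ring) in place of a group of 8 heavy atoms (5 carbon, 2 nitrogen, 1 sulfur; no ring), on a saturated chain carbon, four bonds along the chain from an aromatic nitrogen, leaves the read-out in this assay a number 66.8 percentage points higher from compound 1 to compound 3 (beyond the scatter). Among the compounds shown here, the earlier pair differed in several places at once, so this is the first sign that a change at this position alone can move the read-out by a large step on this core. No measured evidence is available that accounts for the size of this step.

The exchanged groups differ along their whole length, so the compounds shown leave open whether the step belongs to the chain or to its terminal group. A longer chain ending in the same nitrile-bearing group, or a urea with oxygen in place of the sulfur on the chain of compound 1, would separate the two parts of the change.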